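Swapping a dichlorophenyl for methoxyphenyl in a growth-inhibition series

The source may report more compounds than this note shows. Statements on the series, on what has been measured and on what is new or still open speak of the compounds shown alone.

Compound 1, `CCOC(=O)[C@H](CCC(=O)O)NC(=O)c1ccc(CNc2nc3cc(N)cc(N)c3nc2-c2ccccc2)cc1`, and compound 2, `Nc1cc(N)c2nc(-c3ccccc3)c(NCc3ccc(Cl)c(Cl)c3)nc2c1`, share one core and were tested in a functional assay on SF-268 cells (Homo sapiens) for inhibition, read by sulforhodamine B assay, with a stated time of 48 h; a lower number here means a stronger inhibitor of growth, a higher number a weaker inhibitor of growth. Compound 1 gives only a limit here, < 100000 nM, and not a number. Going by the values given here, compound 2 gives 20000 nM, the only true number in this set, so it stands alone as the reference point. Compound 3, `COc1ccc(CNc2nc3cc(N)cc(N)c3nc2-c2ccccc2)cc1`, differs from compound 2 by 4-methoxyphenyl in place of 3,4-dichlorophenyl on a saturated chain carbon bound to a nitrogen on an aromatic ring. Among the compounds with values here, no step between measured compounds exists to guide this change, so a modest step toward weaker inhibition, near the scatter, is expected, a 1.5-fold higher number from compound 2 to compound 3 (0.18 log units; within the scatter). Compound 3 is therefore estimated at 30000 nM, between 8000 nM and 100000 nM.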

Compound 3, concentration for 50% growth inhibition: 9770 nM
Compound 3: middle estimate off by 3.1-fold (0.49 log units), on the high side, within the range that was stated.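

At this place, on a saturated chain carbon bound to a nitrogen on an aromatic ring, 4-methoxyphenyl in place of 3,4-dichlorophenyl gives a 2.0-fold lower number from compound 2 to compound 3 (0.31 log units; beyond the scatter) in this assay, so the dichloro pattern is not needed to keep growth inhibition. Compound 1 gives < 100000 nM, which is a limit and not a number, so steps to it cannot be read. Nothing shown here accounts for the step.

Going by these compounds, whether losing the chlorines or gaining the methoxy drives this step stays open. A plain phenyl, or an amine or carboxylic acid in place of the methoxy, would help separate the two.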